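A few compounds are considered here, and "the series" means these few. Any claim that something is new, unique, unknown or untested is made for them only; others in the source may bear on it.

Series notes. Compound 1 `COc1cccc(-c2cccc(NC(=O)CCc3ccc4c(c3)COB4O)c2)c1` gives 81000 nM in a functional assay on HCT-116 cells (Homo sapiens) for antiproliferative activity, read by MTT assay, with a stated time of 72 h; on this read-out higher numbers stand for weaker inhibition and lower numbers for stronger inhibition. Compound 2 `COc1cc(OC)cc(-c2cccc(NC(=O)CCc3ccc4c(c3)COB4O)c2)c1` carries the same core with one change, (methoxy in place of hydrogen on an aromatic carbon), and in this assay compound 2 gives 56000 nM; the step is a 1.4-fold lower number from compound 1 to compound 2 (0.16 log units; within the scatter). Compound 3 `COc1cccc(-c2cccc(NC(=O)CCc3ccccc3)c2)c1` has a different core; the difference between the two cores is not broken down here. In this assay compound 3 gives 40000 nM. Compound 4 `COc1cc(OC)cc(-c2cccc(NC(=O)CCc3ccccc3)c2)c1` has not yet been measured; it differs from compound 3 by methoxy in place of hydrogen on an aromatic carbon, the same change as that from compound 1 to compound 2, at the same place by the same description, so the two are taken as one kind of step on two cores. For the measured compounds named here, with only one prior instance of the change, and that one within the scatter, no direction can be claimed; the step from compound 3 to compound 4 in this assay is expected to be about a 1.3-fold lower number from compound 3 to compound 4 (0.12 log units; within the scatter), resting on the single earlier step of a 1.4-fold lower number from compound 1 to compound 2 (0.16 log units; within the scatter). The estimate for compound 4 in this assay is therefore 30000 nM, with a plausible range from 12000 nM to 75000 nM.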

Compound 4, half-maximal inhibitory concentration: > 100000 nM
Compound 4 gave a limit, no number; the forecaster's own chance of this, stated with the estimate: 5%; middle value at least 3.3-fold (0.52 log units) from the limit.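

In this assay compound 4 gives > 100000 nM, which is a limit of the assay and not a number. Even so, methoxy in place of hydrogen on an aromatic carbon does not carry over from the core of compound 1 to the core of compound 3, as the two steps differ: the same change on two cores in this assay, a 1.4-fold lower number (0.16 log units; within the scatter) from compound 1 to compound 2 and an at least 2.5-fold higher number (0.39 log units; beyond the scatter) from compound 3 to compound 4, at least 3.6-fold (0.55 log units) apart, beyond the scatter of two such steps

This does not fix the size of the step on the second core, since an at least 2.5-fold higher number from compound 3 to compound 4 (0.39 log units; beyond the scatter) gives only a floor; the change of core with the methoxy groups held, an at least 1.7-fold higher number from compound 2 to compound 4 (0.25 log units; that floor lies within the scatter), has a floor that allows no order to be stated, and one pair on each core gives no rule for any other core.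

Open, going by these compounds, is whether a different group at the same aromatic carbon, such as fluoro, hydroxyl or an amine, would also behave differently on the two cores. Also open, on these data alone, is whether the same split would appear with a longer chain between the amide carbonyl and the ring.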